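The source may report more compounds than this note shows. Statements on the series, on what has been measured and on what is new or still open speak of the compounds shown alone.

Compound 2 `O=C(O)C[C@@H]1CCCN1c1ccc(Oc2cccc(Cl)c2)cc1` stands at the higher end of the two numbers: in a functional assay on cells for agonist activity at Free fatty acid receptor 1 (Homo sapiens), read by FLIPR and calcium flux, with a stated time of 100 s (on this read-out lower numbers stand for an effect already at smaller amounts and higher numbers for an effect only at larger amounts of compound), compound 2 gives 680 nM, while compound 1 `O=C(O)C[C@@H]1CCCN1c1ccc(Oc2ccccc2F)cc1` gives 150 nM. Within the data shown here, that gap is the single measured step, a 4.5-fold higher number from compound 1 to compound 2 (0.66 log units; beyond the scatter), and it shows that exchanging the ring on the aryl ether oxygen moves the read-out beyond the scatter. Compound 3 `COc1ccc(Oc2ccc(N3CCC[C@H]3CC(=O)O)cc2)cc1` carries 4-methoxyphenyl in place of 3-chlorophenyl on an oxygen on an aromatic ring. Among the measured compounds shown here, no measured step covers a 4-methoxyphenyl, so the size of the one known step is the only guide, and a shift of comparable size in either direction remains possible. The expected step is a 1.4-fold lower number from compound 2 to compound 3 (0.13 log units; within the scatter). Compound 3 is estimated at 500 nM, with a range from 150 nM to 1600 nM.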

Compound 3, half-maximal effective concentration: 520 nM
Compound 3: the middle estimate sits 1.0-fold (0.02 log units) below what was measured; the measured number falls inside the stated range.
By their numbers in this assay, from the lowest: compound 1; then compounds 3 and 2 (each within the scatter of the next).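

On the oxygen on an aromatic ring, in this assay, 4-methoxyphenyl in place of 3-chlorophenyl gives a 1.3-fold lower number from compound 2 to compound 3 (0.12 log units; within the scatter), so a second substituted ring, one with a hydrogen-bond acceptor, does not separate from compound 2. The same group in place of 2-fluorophenyl gives a 3.5-fold higher number from compound 1 to compound 3 (0.54 log units; beyond the scatter), leaving compound 1 apart from both other compounds. No evidence on hand accounts for these steps.

On these data alone, whether that gap belongs to the fluorine itself or to where it sits stays open. An unsubstituted phenyl and a 4-fluorophenyl are not among the compounds shown.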